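The source may hold more compounds than are shown below. What is called first, only, known or untested is meant among the compounds shown, and "the series" means these compounds.

In a functional assay on HeLa cells (Homo sapiens) for antiproliferative activity, read by MTT assay, with a stated time of 48 h (on this read-out higher numbers stand for weaker inhibition of growth and lower numbers for stronger inhibition of growth), compound 2 `Cc1cc2c(c(=O)n1C)C(c1ccc(F)c(Br)c1)C(C#N)=C(N)O2` gives 6400 nM, the only numerical result among the three measured compounds. Compound 1 `Cc1cc2c(c(=O)n1C)C(c1ccc(C(C)C)cc1)C(C#N)=C(N)O2` gives only a limit, > 100000 nM. Compound 3 `Cc1cc2c(c(=O)o1)C(c1cccc(Br)c1)C(C#N)=C(N)O2`, built on a different core, likewise gives only a limit, > 100000 nM. Two of the three results therefore sit at the limit of > 100000 nM in this assay, at which 2 of the 3 values shown sit. Compound 4 `Cc1cc2c(c(=O)n1C)C(c1cccc(Br)c1)C(C#N)=C(N)O2` is compound 2 with hydrogen in place of fluoro on an aromatic carbon. Going by the values given here, no step between measured compounds is available to size this change, and the expectation rests on compound 2 alone. Compound 4 is expected to show a step of a 2.3-fold higher number from compound 2 to compound 4 (0.37 log units; beyond the scatter), a modest weakening that may just exceed the usual scatter. Compound 4 is accordingly estimated at 15000 nM, with a range from 4000 nM to 100000 nM.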

Compound 4, concentration for 50% growth inhibition: 6500 nM
Compound 4: the middle estimate sits 2.3-fold (0.36 log units) above what was measured; the measured number falls inside the stated range.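

In this assay, hydrogen in place of fluoro on the aromatic carbon gives a 1.0-fold higher number from compound 2 to compound 4 (0.01 log units; within the scatter), so the two compounds cannot be told apart. At this position, ortho to a bromo group and para to a large group, fluoro is thus not required for the growth inhibition seen with compound 2. Nothing shown here offers a reason for this result. On these data alone, it remains open whether a methoxy group, a chloro group or an amine at this position would shift the value, and whether the bromo group itself is needed.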